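This account rests on a few compounds, and the source may have more. Where it says the series, first, only, none or still open, it means among the compounds named here.

Compound 1 `CC(=O)c1cc(-c2ccccc2)cc2cc(-c3ccc(F)cc3)[nH]c12` gives 91.1% in a functional assay on HeLa cells (Homo sapiens) for cytotoxicity, read by MTT assay, with a stated time of 2 days, tested at 0.1 uM; a lower number here means a stronger effect, a higher number a weaker effect of the compound at the concentration tested.
Compound 2 `COc1ccc(-c2cc(C(C)=O)c3[nH]c(-c4ccc(F)cc4)cc3c2)cc1` gives 74.5% in this assay.
Compound 3 `COc1ccc(-c2cc3cc(-c4ccccc4)cc(C(C)=O)c3[nH]2)cc1` gives 80.5% in this assay.

Among these three numbers compound 3 stands second highest in this assay. Its nearest neighbour is compound 2, whose number lies within the scatter of that of compound 3, so no order can be claimed between the two. Compound 1 stands furthest away, and the gap is a measured step beyond the scatter: a number 10.6 percentage points lower from compound 1 to compound 3 (beyond the scatter).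

Compound 4 `COc1ccc(-c2cc(C(C)=O)c3[nH]c(-c4ccc(OC)cc4)cc3c2)cc1` has not yet been measured. The change from compound 3 to compound 4 is methoxy in place of hydrogen on an aromatic carbon; cut one bond further out, the same difference reads phenyl to 4-methoxyphenyl. Within the data shown here, two measured steps bear on it. The same kind of change, made elsewhere in the molecule, gave a number 16.6 percentage points lower from compound 1 to compound 2 (beyond the scatter), a modest lowering beyond the scatter. Compound 4 also relates to compound 2 as compound 3 relates to compound 1, and that step was a number 10.6 percentage points lower from compound 1 to compound 3 (beyond the scatter), again a modest lowering. Both routes point the same way, so compound 4 is expected to show a modest drop beyond the scatter, a number 16.5 percentage points lower from compound 3 to compound 4 (beyond the scatter). The estimate for compound 4 in this assay is 64%, within the range 50% to 78%.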

Compound 4, a percentage reported as activity, at one concentration (the size of the read-out at that concentration, not a potency): 74.5%
Compound 4: middle estimate off by 10.5 percentage points, on the low side, and the stated range covers the measured number.
By their numbers in this assay, from the lowest: compounds 2, 4 and 3 (each within the scatter of the next); then compound 1.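

In this assay, turning phenyl into 4-methoxyphenyl gives a number 6 percentage points lower from compound 3 to compound 4 (within the scatter), so at this position the change cannot be told apart from the spread of repeated measurements, and compounds 2, 3 and 4 all lie within the scatter of one another. Methoxy in place of fluoro on the other aromatic ring likewise gives no change at the digits printed from compound 2 to compound 4 (within the scatter), so a second methoxy adds nothing that can be read from these numbers, and this step does not truly differ from its earlier counterpart: the same change on two cores in this assay, a number 10.6 percentage points lower (beyond the scatter) from compound 1 to compound 3 and no change at the digits printed (within the scatter) from compound 2 to compound 4, 10.6 percentage points apart, within the scatter of two such steps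
The smaller size of the hydrogen-to-methoxy step on this core cannot be called a real difference between the cores either, so the earlier step and the new one remain compatible: the same change on two cores in this assay, a number 16.6 percentage points lower (beyond the scatter) from compound 1 to compound 2 and a number 6 percentage points lower (within the scatter) from compound 3 to compound 4, 10.6 percentage points apart, within the scatter of two such steps

At this position, the compounds shown carry only hydrogen, fluoro or methoxy, and it stays open how an amine, a carboxylic acid or a longer chain such as butoxy would read there. On these data alone, each number is also a read-out at one concentration, and how the compounds would rank across a range of concentrations stays unknown.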